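The compounds below may be only part of what the source reports. "The series", "measured", "known", "first", "only" and "open" are said of these compounds alone.

Compound 1 `O=[N+]([O-])c1cccc(/N=N/N2CCCC2)c1`: in an ADME assay on MT4 cells (Homo sapiens) for cytotoxicity, read by MTT assay, with a stated time of 96 h (a lower number here means that less compound is tolerated, a higher number that more compound is tolerated), compound 1 gives 66000 nM.
Compound 2 `c1ccc(/N=N/N2CCCC2)cc1`: compound 2 gives > 100000 nM, which is a limit of the assay rather than a number.
Compound 3 `Clc1cccc(/N=N/N2CCCC2)c1`: compound 3 gives > 100000 nM, also a limit of the assay.

Compound 2 therefore stands at the ceiling of what this assay can report, as does compound 3: the limit of > 100000 nM in this assay, at which 2 of the 3 values shown sit. Only compound 1, with its nitro group, gives a measurable number, and the step of an at least 1.5-fold higher number from compound 1 to compound 2 (0.18 log units; that floor lies within the scatter) shows that taking the nitro away moves the value up, though by an amount whose floor lies within the scatter.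

Compound 4 `Brc1ccc(/N=N/N2CCCC2)cc1` differs from compound 2 by the change (bromo in place of hydrogen on an aromatic carbon). The closest measured step is a step that the two limits leave unreadable from compound 2 to compound 3, where a halogen enters in a similar way and both ends sit at the limit, so its size cannot be read. For the measured compounds named here, nothing among the measured compounds points to a bromo group pushing the value down toward the range of compound 1.

In this assay compound 4 is therefore expected at 150000 nM, with a range from 60000 nM to 400000 nM, most likely reported again as a limit. That estimate means an expected step that the limit leaves unreadable from compound 2 to compound 4.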

Compound 4, half-maximal cytotoxic concentration: > 100000 nM
Compound 4 was reported as a limit (the forecaster's own chance of this, stated with the estimate: 75%); the middle value does not contradict the limit.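

Compound 4, like compound 2, gives only a limit of the assay and not a number, so no step between them can be read: the limit of > 100000 nM in this assay, at which 3 of the 4 values shown sit.

The compounds shown leave open whether bromo in place of hydrogen changes the tolerated concentration at all.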